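A few compounds are considered here, and "the series" means these few. Any claim that something is new, unique, unknown or untested is made for them only; others in the source may bear on it.

Compound 2 `O=C(NCc1ccccc1)c1cc(Oc2ccc(/C=C/c3ccccn3)cc2)ccn1` carries the same core as compound 1 `O=C(Nc1ccccc1)c1cc(Oc2ccc(/C=C/c3ccccn3)cc2)ccn1` and differs from it by a benzyl in place of a phenyl on the amide-type nitrogen. Among the measured compounds shown here, in a functional assay on HepG2 cells (Homo sapiens) for antiproliferative activity, read by CCK-8 assay, with a stated time of 48 h (a higher number here means a weaker inhibitor, a lower number a stronger inhibitor), compound 1 gives 30200 nM and compound 2 gives 27900 nM; the step of a 1.1-fold lower number from compound 1 to compound 2 (0.03 log units; within the scatter) is the single measured step. Compound 2 thus holds the lowest of the two numbers in this assay, but its separation from compound 1 lies within the scatter, so no order between the two can be read.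

Compound 3 `O=C(NCc1ccc(F)cc1)c1cc(Oc2ccc(/C=C/c3ccccn3)cc2)ccn1` differs from compound 2 by fluoro in place of hydrogen on an aromatic carbon, placed on an aromatic carbon of a six-membered aromatic ring of carbon only, para to a large group. For the measured compounds named here, no measured step touches this ring position. Going by the values given here, the one step available, a 1.1-fold lower number from compound 1 to compound 2 (0.03 log units; within the scatter), changed the whole group on the amide nitrogen and gave nothing beyond the scatter, and it bears only loosely on a single fluoro substitution. With no closer guide, the expected step of a 1.1-fold lower number from compound 2 to compound 3 (0.05 log units; within the scatter) is none beyond the scatter. Compound 3 is therefore estimated at 25000 nM in this assay, with a range from 10000 nM to 60000 nM.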

Compound 3, half-maximal inhibitory concentration: 45100 nM
Beside the measured number, compound 3's estimate is 1.8-fold (0.26 log units) below it; low and high end bracket the measured number.
By their numbers in this assay, from the lowest: compounds 2, 1 and 3 (each within the scatter of the next).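

In this assay, among the compounds shown here, this is the first reading of the six-membered aromatic ring of the benzyl group: fluoro in place of hydrogen on an aromatic carbon, para to a large group, gives a 1.6-fold higher number from compound 2 to compound 3 (0.21 log units; within the scatter), so this single-atom change does not separate the two compounds. The wider change on the amide-type nitrogen, 4-fluorobenzyl in place of phenyl, gives a 1.5-fold higher number from compound 1 to compound 3 (0.17 log units; within the scatter), so neither the fluoro nor the swap of the whole group yields a step beyond the scatter in this small set. No measurement is available that bears on these steps.

On these data alone, whether this ring position is insensitive in general remains open, as one fluoro cannot speak for other groups there, such as a chloro, a methoxy or an amine. Also open, as far as these compounds go, is whether a carboxylic acid on the same ring, or a longer chain in place of benzyl on the amide-type nitrogen, would move the number beyond the scatter.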